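Side chain at the amino acid position and lipophilicity

This account rests on a few compounds, and the source may have more. Where it says the series, first, only, none or still open, it means among the compounds named here.

Compound 3 `COc1cc(NC(C)CCCN2C(=O)CN(C(=O)CN)C2(C)C)c2ncccc2c1` gives 2.19 in a physicochemical assay for lipophilicity, measured as octanol-water partition (on this read-out higher numbers stand for higher lipophilicity and lower numbers for lower lipophilicity), the lowest of the three numbers measured. Compound 1 `COc1cc(NC(C)CCCN2C(=O)CN(C(=O)[C@H](N)CCSC)C2(C)C)c2ncccc2c1` gives 2.94 and compound 2 `COc1cc(NC(C)CCCN2C(=O)CN(C(=O)[C@H](N)CC(C)C)C2(C)C)c2ncccc2c1` gives 3.36; the steps of a number 0.75 log units lower from compound 1 to compound 3 (beyond the scatter) and a number 1.17 log units lower from compound 2 to compound 3 (beyond the scatter) are both beyond the scatter, as is a number 0.42 log units higher from compound 1 to compound 2 (beyond the scatter). Compound 4 `CC[C@H](C)[C@@H](N)C(=O)N1CC(=O)N(CCCC(C)Nc2cc(OC)cc3cccnc23)C1(C)C` carries sec-butyl in place of hydrogen on a saturated chain carbon bound to an amine nitrogen and a carbonyl carbon. The step from compound 2 to compound 3, which removed isobutyl, bears most directly on this change, isobutyl to sec-butyl being a change of branching alone; the step from compound 1 to compound 3 points the same way. A rise of comparable size is therefore expected in this assay, a number 1.11 log units higher from compound 3 to compound 4 (beyond the scatter). Compound 4 is estimated at 3.3, with a range of 2.95 to 3.65.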

Compound 4, partition coefficient: 3.4
Compound 4: middle estimate off by 0.10 log units, on the low side; the measured number falls inside the stated range.
By their numbers in this assay, from the lowest: compound 3; then compound 1; then compounds 2 and 4 (each within the scatter of the next).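

At this position in this assay, sec-butyl in place of hydrogen gives a number 1.21 log units higher from compound 3 to compound 4 (beyond the scatter) and so repeats the large rise seen with isobutyl. Sec-butyl in place of isobutyl gives a number 0.04 log units higher from compound 2 to compound 4 (within the scatter), so this change of branching is not resolved here. Sec-butyl in place of 2-(methylsulfanyl)ethyl gives a number 0.46 log units higher from compound 1 to compound 4 (beyond the scatter) and matches the direction of the isobutyl step.

On these data alone, how a carboxylic acid, an amine or a longer chain on this carbon would read remains open. No supporting evidence bears on these numbers.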